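This account rests on a few compounds, and the source may have more. Where it says the series, first, only, none or still open, it means among the compounds named here.

In a functional assay on MCF7 cells (Homo sapiens) for cytotoxicity, read by sulforhodamine B assay, with a stated time of 48 h; on this read-out higher numbers stand for weaker inhibition and lower numbers for stronger inhibition:
Compound 1 `Nc1c(-c2nc3ccccc3[nH]2)cc(-c2ccccc2)n1-c1ccc(Cl)cc1`: 934 nM
Compound 2 `Nc1c(-c2nc3ccccc3[nH]2)cc(-c2ccccc2)n1-c1nc2ccccc2[nH]1`: 1620 nM

Within the data shown here, compound 2 lies within the scatter of compound 1, the only other compound measured. Among the measured compounds shown here, the one measured step, a 1.7-fold higher number from compound 1 to compound 2 (0.24 log units; within the scatter), exchanged the group on the same aromatic nitrogen that changes next. Compound 3 `Nc1c(-c2nc3ccccc3[nH]2)cc(-c2ccccc2)n1Cc1nc2ccccc2[nH]1` differs from compound 2 as follows: (1H-benzimidazol-2-yl)methyl in place of 1H-benzimidazol-2-yl on an aromatic nitrogen. For the measured compounds named here, no measured compound carries (1H-benzimidazol-2-yl)methyl, so the evidence is thin. Going by the values given here, with only that one small step to go on, no change beyond the scatter is expected in this assay. The expected step is a 1.1-fold lower number from compound 2 to compound 3 (0.03 log units; within the scatter). For compound 3 the estimated value is 1500 nM, with an expected range of 500 nM to 4500 nM.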

Compound 3, half-maximal inhibitory concentration: 972 nM
For compound 3 the middle estimate is 1.5-fold (0.19 log units) above the measured one, and the stated range covers the measured number.
By their numbers in this assay, from the lowest: compounds 1, 3 and 2 (each within the scatter of the next).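

In this assay, placing (1H-benzimidazol-2-yl)methyl on the aromatic nitrogen instead of 1H-benzimidazol-2-yl gives a 1.7-fold lower number from compound 2 to compound 3 (0.22 log units; within the scatter) and shows that the added methylene link leaves the number within the scatter. Set against 4-chlorophenyl, the same group gives a 1.0-fold higher number from compound 1 to compound 3 (0.02 log units; within the scatter) and so all three groups tried on this nitrogen stand within the scatter of one another. The data offer no measurement that would explain this.

As far as these compounds go, whether an amine, a carboxylic acid or a longer alkyl chain on this nitrogen would move the number beyond the scatter remains open.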